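Taking the chloro group off compound 2

The source may report more compounds than this note shows. Statements on the series, on what has been measured and on what is new or still open speak of the compounds shown alone.

Measured in a functional assay on HOP-92 cells (Homo sapiens) for inhibition, read by sulforhodamine B assay, with a stated time of 48 h, tested at 10 uM (on this read-out lower numbers stand for less inhibition of growth and higher numbers for more inhibition of growth at the one concentration tested), so far:
compound 1 `COc1ccc(-c2nc3sc(-c4ccccc4)cn3n2)cc1` gives 32%
compound 2 `Clc1ccc(-c2cn3nc(-c4ccccc4)nc3s2)cc1` gives 53%
compound 3 `COc1ccc(-c2nc3sc(-c4ccc(Cl)cc4)cn3n2)cc1` gives 79.5%

Compound 2 holds the second highest number of the three, with compound 1 lower and compound 3 higher, and both gaps lie beyond the scatter. The next compound is compound 4 `c1ccc(-c2nc3sc(-c4ccccc4)cn3n2)cc1` and its difference from compound 2 is hydrogen in place of chloro on an aromatic carbon. Going by the values given here, the closest precedent is the same exchange in the opposite sense, chloro in place of hydrogen on an aromatic carbon, seen in the large step of a number 47.5 percentage points higher from compound 1 to compound 3 (beyond the scatter) and this lies beyond the scatter. Compound 4 also lacks the methoxy group, and the modest step of a number 26.5 percentage points higher from compound 2 to compound 3 (beyond the scatter) shows what methoxy in place of hydrogen on an aromatic carbon did with the chloro group present. Whether such steps carry over unchanged is not known from three compounds. A large downward move in this assay is therefore expected, and the estimated step is a number 41 percentage points lower from compound 2 to compound 4 (beyond the scatter) in this reading. Compound 4 is expected at 12% within a range from 0% to 32% as the estimate.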

Compound 4, percent growth inhibition at one concentration: 25%
For compound 4 the middle estimate is 13 percentage points below the measured one; measured number inside the range.
By their numbers in this assay, from the lowest: compounds 4 and 1 (each within the scatter of the next); then compound 2; then compound 3.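

In this assay, the chloro group on the 4-chlorophenyl ring counts even where no methoxy group is present, since hydrogen in its place gives a number 28 percentage points lower from compound 2 to compound 4 (beyond the scatter). The size of the chloro step nevertheless depends on the group elsewhere in the molecule, so it cannot be treated as a fixed increment: the same change on two cores in this assay, a number 47.5 percentage points higher (beyond the scatter) from compound 1 to compound 3 and a number 28 percentage points higher (beyond the scatter) from compound 4 to compound 2, 19.5 percentage points apart, beyond the scatter of two such steps. Methoxy shows the same dependence in the other direction, with hydrogen in its place giving a number 7 percentage points lower from compound 1 to compound 4 (within the scatter) when no chloro group is present, whereas the step with chloro present is far clearer: the same change on two cores in this assay, a number 26.5 percentage points higher (beyond the scatter) from compound 2 to compound 3 and a number 7 percentage points higher (within the scatter) from compound 4 to compound 1, 19.5 percentage points apart, beyond the scatter of two such steps.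

From the compounds shown here alone, it remains open whether this interplay belongs to chloro itself or would also appear with another group on that aromatic carbon, such as an amine or a carboxylic acid. The compounds shown also leave open whether the pattern extends beyond these four compounds to other substituted analogues.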